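The compounds below may be only part of what the source reports. "The series", "measured", "known", "first", "only" and "open" are said of these compounds alone.

Measured compounds:
compound 1 `Oc1cccc(CNc2cc(Br)cc3[nH]ncc23)c1`: 45%
compound 2 `FC(F)(F)c1cccc(CNc2cc(Br)cc3[nH]ncc23)c1`: 16%

In an assay for inhibition of Indoleamine 2,3-dioxygenase 1 (Homo sapiens), with a stated time of 1 h, tested at 10 uM (a lower number here means less inhibition, a higher number more inhibition at the concentration tested (going by the name of the read-out)), compound 1 gives 45%, the higher of the two numbers shown. Compound 2 gives 16%, with a number 29 percentage points lower from compound 1 to compound 2 (beyond the scatter) beyond the scatter. Compound 3 `Oc1ccc(CNc2cc(Br)cc3[nH]ncc23)cc1O` is not yet measured and differs from compound 1 by hydroxy in place of hydrogen on an aromatic carbon, the entering hydroxy standing ortho to the hydroxy already present and para to the large group. For the measured compounds named here, no measured step adds a hydroxy; the one step known only replaces it. Compound 3 is therefore expected near compound 1, with a number 5 percentage points higher from compound 1 to compound 3 (within the scatter) within the scatter. The estimate for compound 3 is 50%, range 25% to 75%.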

Compound 3, a percentage reported as inhibition, at one concentration (the size of the read-out at that concentration, not a potency): 50%
Compound 3: the middle estimate sits on the measured number at the digits printed, and the stated range covers the measured number.
By their numbers in this assay, from the lowest: compound 2; then compounds 1 and 3 (each within the scatter of the next).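

In this assay, hydroxy in place of hydrogen, ortho to a hydroxy group and para to a large group, gives a number 5 percentage points higher from compound 1 to compound 3 (within the scatter), so this position takes a second hydroxy without a change beyond the scatter. The earlier step only replaced the existing hydroxy, whereas this one keeps it and shows that the ring carbon can also be substituted. No supporting data bear on this result.

As far as these compounds go, whether the added hydroxy would give the same reading without the hydroxy already present remains open. Also open, from the compounds shown here alone, is how a methoxy or an amine would read at this position.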